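Replacing the side chain of compound 2 with piperidin-1-yl

A few compounds are considered here, and "the series" means these few. Any claim that something is new, unique, unknown or untested is made for them only; others in the source may bear on it.

In a functional assay on A549 cells (Homo sapiens) for cytotoxicity, read by MTT assay, with a stated time of 72 h (on this read-out lower numbers stand for stronger inhibition and higher numbers for weaker inhibition), compound 1 (`O=C1c2c[n+]([O-])c3ccccc3c2C(=O)c2c1c1ccccc1n2CCCCn1ccnc1`) gives 170 nM. Compound 2 (`CCCN1CCN(CCCCn2c3c(c4ccccc42)C(=O)c2c[n+]([O-])c4ccccc4c2C3=O)CC1`) gives 320 nM, which lies within the scatter of compound 1, so the two numbers cannot be separated. Compound 3 (`O=C1c2c[n+]([O-])c3ccccc3c2C(=O)c2c1c1ccccc1n2CCN1CCCCC1`) has not yet been measured. Its difference from compound 2 is piperidin-1-yl in place of 2-(4-propylpiperazin-1-yl)ethyl on a saturated chain carbon, two bonds along the chain from an aromatic nitrogen. Among the compounds with values here, only one measured step bears on this, a 1.9-fold higher number from compound 1 to compound 2 (0.27 log units; within the scatter), which exchanged the end group and stayed within the scatter. Within the data shown here, no measured pair isolates the shorter chain, so the evidence is thin. The expected change is therefore a 1.3-fold lower number from compound 2 to compound 3 (0.11 log units; within the scatter), with no shift expected beyond the scatter. For compound 3 the estimated value is 250 nM, with an expected range of 100 nM to 650 nM.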

Compound 3, half-maximal inhibitory concentration: 1080 nM
Estimate against measurement, compound 3: 4.3-fold (0.64 log units) below; the measured number lies above the stated range.
By their numbers in this assay, from the lowest: compounds 1 and 2 (each within the scatter of the next); then compound 3.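

In this assay, this change is the first shown to move the number beyond the scatter: a 3.4-fold higher number from compound 2 to compound 3 (0.53 log units; beyond the scatter), and a 6.4-fold higher number from compound 1 to compound 3 (0.80 log units; beyond the scatter). The side chain is therefore not indifferent to every replacement, although the earlier exchange of end groups alone gave no sign of this. Nothing available explains the shift.

Compound 3 differs from compound 1 and compound 2 in both chain length and end group, so the compounds shown leave open whether the shorter chain, the piperidin-1-yl ring or the two together account for the higher number; piperidin-1-yl on the longer chain of compound 1 would separate these. Also open, going by these compounds, is how a morpholin-4-yl group or a primary amine at the chain end would read on either chain.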